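The source may hold more compounds than are shown below. What is called first, only, known or untested is meant among the compounds shown, and "the series" means these compounds.

Measured in a functional assay on HCT-116 cells (Homo sapiens) for antiproliferative activity, read by MTT assay, with a stated time of 48 h; a lower number here means a stronger inhibitor, a higher number a weaker inhibitor:
compound 1 `COc1ccc(-c2cc3c(cn2)[nH]c(=O)n3-c2cc(OC)c(OC)c(OC)c2)cc1` gives 840 nM
compound 2 `COc1ccc(-c2cc3c(cn2)[nH]c(=O)n3-c2cc(OC)c(OC)c(OC)c2)cc1O` gives 340 nM
compound 3 `COc1ccc(-c2cc3c(cn2)[nH]c(=O)n3-c2cc(OC)c(OC)c(OC)c2)cn1` gives 830 nM

Compound 3 (830 nM) stands with compound 1 at the high end of these three numbers, the two lying within the scatter of each other, while compound 2 lies lower.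

Compound 4 `COc1ccc(-c2cc3c(cn2)[nH]c(=O)n3-c2cc(OC)c(OC)c(OC)c2)cc1N` carries 3-amino-4-methoxyphenyl in place of 6-methoxypyridin-3-yl on an aromatic carbon. Going by the values given here, no amino compound has been measured, so the reading is indirect. The swap of 4-methoxyphenyl for 6-methoxypyridin-3-yl changed nothing beyond the scatter (a 1.0-fold lower number from compound 1 to compound 3 (0.01 log units; within the scatter)), which makes compound 1 a fair baseline for this step. Adding hydroxy gave a modest gain (a 2.5-fold lower number from compound 1 to compound 2 (0.39 log units; beyond the scatter)), and leaving the 3-hydroxy-4-methoxyphenyl of compound 2 for the group of compound 3 gave a modest loss (a 2.4-fold higher number from compound 2 to compound 3 (0.39 log units; beyond the scatter)). If amino behaves as hydroxy does here, which remains an assumption, the number should fall.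

A modest move to a lower number is expected (a 2.6-fold lower number from compound 3 to compound 4 (0.41 log units; beyond the scatter)). The estimate for compound 4 is 320 nM (expected range 110 nM to 900 nM).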

Compound 4, half-maximal inhibitory concentration: 820 nM
The estimate for compound 4 lay 2.6-fold (0.41 log units) below the measured number; low and high end bracket the measured number.
By their numbers in this assay, from the lowest: compound 2; then compounds 4, 3 and 1 (each within the scatter of the next).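

In this assay, amino does not repeat the gain seen with hydroxy: adding it to the 4-methoxyphenyl group leaves the number within the scatter (a 1.0-fold lower number from compound 1 to compound 4 (0.01 log units; within the scatter)), and exchanging hydroxy for amino costs a modest amount (a 2.4-fold higher number from compound 2 to compound 4 (0.38 log units; beyond the scatter)). The 3-amino-4-methoxyphenyl and 6-methoxypyridin-3-yl groups cannot be told apart here (a 1.0-fold lower number from compound 3 to compound 4 (0.01 log units; within the scatter)), so among the four compounds only the 3-hydroxy-4-methoxyphenyl group of compound 2 stands clear of the others. No measurement shown explains why hydroxy and amino differ at this carbon.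

From the compounds shown here alone, whether a fluorine, a methylamino or an acetamido group at the same carbon would track hydroxy or amino remains open. Also open, going by these compounds, is whether hydroxy would bring a similar gain on a different aromatic ring in this position.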